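From phenoxy to trifluoromethoxy on a shared core

A few compounds are considered here, and "the series" means these few. Any claim that something is new, unique, unknown or untested is made for them only; others in the source may bear on it.

Of the compounds shown here, three sharing one core have been read in a functional assay on Jurkat cells (Homo sapiens); a lower number here means a stronger inhibitor, a higher number a weaker inhibitor. Compound 1 `CC(C)[C@H](NC(=O)COc1cccc2ccccc12)C(=O)N[C@@H](CC(=O)O)C(=O)COc1ccc(C(F)(F)F)cc1` gives > 100000 nM, which is a limit of the assay and not a number. Compound 2 `CC(C)[C@H](NC(=O)COc1cccc2ccccc12)C(=O)N[C@@H](CC(=O)O)C(=O)COc1ccc(C(N)=O)cc1` gives > 100000 nM, which is likewise only a limit. Among the compounds with values here, compound 3 `CC(C)[C@H](NC(=O)COc1cccc2ccccc12)C(=O)N[C@@H](CC(=O)O)C(=O)COc1ccc(Oc2ccccc2)cc1` gives 12700 nM, the only true number among the three.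

Compound 4 `CC(C)[C@H](NC(=O)COc1cccc2ccccc12)C(=O)N[C@@H](CC(=O)O)C(=O)COc1ccc(OC(F)(F)F)cc1` departs from compound 3 by one change: trifluoromethyl in place of phenyl on an oxygen on an aromatic ring. In words, this is trifluoromethyl in place of phenyl on an oxygen on an aromatic ring, so that phenoxy becomes trifluoromethoxy.

Within the data shown here, two measured steps bear on this change: an at least 7.8-fold lower number from compound 1 to compound 3 (0.89 log units; beyond the scatter) and an at least 7.8-fold lower number from compound 2 to compound 3 (0.89 log units; beyond the scatter). Going by these compounds, both lead to the phenoxy group of compound 3, and both are bounded by a limit at one end, so their true sizes remain open. Compound 1 is the closer guide, as it too lacks phenoxy and carries trifluoromethyl. Losing phenoxy is therefore expected to raise the number in this assay, though the added oxygen leaves the size uncertain. The expected change is a 3.9-fold higher number from compound 3 to compound 4 (0.60 log units; beyond the scatter), and a reading at the limit would be no surprise. For compound 4 the estimate is 50000 nM, with an expected range from 15000 nM to 100000 nM.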

Compound 4, half-maximal inhibitory concentration: 29100 nM
Estimate against measurement, compound 4: 1.7-fold (0.24 log units) above, and the stated range covers the measured number.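

In this assay, within the data shown here, compound 4 is the first compound without phenoxy to give a true number rather than a limit, and replacing phenyl with trifluoromethyl on this oxygen brings only a modest loss, with a 2.3-fold higher number from compound 3 to compound 4 (0.36 log units; beyond the scatter). Trifluoromethoxy also stands clear of the two groups that gave only a limit, with an at least 3.4-fold lower number from compound 1 to compound 4 (0.53 log units; beyond the scatter) and an at least 3.4-fold lower number from compound 2 to compound 4 (0.53 log units; beyond the scatter), the first of these changes adding an oxygen between the aromatic carbon and the trifluoromethyl group. Among these four compounds, the two groups attached through an oxygen, phenoxy and trifluoromethoxy, give numbers, whereas trifluoromethyl and carbamoyl do not, so the last two steps are bounded on one side only: the limit of > 100000 nM in this assay, at which 2 of the 4 values shown sit.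

The compounds shown leave open how other groups on this oxygen, such as methyl, ethyl or benzyl, would read, and so how far the number follows what the oxygen carries. Also open, going by these compounds, is whether an amine nitrogen in place of this oxygen, as in an anilino group, would likewise give a number rather than a limit.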